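The compounds below may be only part of what the source reports. "The series", "measured", "known", "first", "only" and "open" are said of these compounds alone.

Compound 1 `COC(=O)c1ccc(C2SCC(=O)N2c2ccc(N3CCN(Cc4cccc(C)c4)CC3)cn2)c(OC)c1` in a functional assay on NALM-6 cells (Homo sapiens) for antiproliferative activity, read by MTT assay and trypan blue exclusion, with a stated time of 72 h (a lower number here means a stronger inhibitor, a higher number a weaker inhibitor), gives 27300 nM.
Compound 2 `COC(=O)c1ccc(C2SCC(=O)N2c2ccc(N3CCN(Cc4cccc([N+](=O)[O-])c4)CC3)cn2)c(OC)c1` in this assay gives only a limit, > 100000 nM.
Compound 3 `COC(=O)c1ccc(C2SCC(=O)N2c2ccc(N3CCN(S(=O)(=O)c4ccc(F)cc4)CC3)cn2)c(OC)c1` in this assay gives only a limit, > 100000 nM.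

Among the measured compounds shown here, compound 3 thus sits at the limit of > 100000 nM in this assay, at which 2 of the 3 values shown sit, with no number of its own; the step of an at least 3.6-fold higher number from compound 1 to compound 3 (0.56 log units; beyond the scatter) places it at least modestly weaker than the one measured compound with a number. Compound 4 `COC(=O)c1ccc(C2SCC(=O)N2c2ccc(N3CCN(Cc4ccc(Cl)c(Cl)c4)CC3)cn2)c(OC)c1` differs from compound 3 by 3,4-dichlorobenzyl in place of (4-fluorophenyl)sulfonyl on an amine nitrogen in a ring. This restores a benzyl group on the ring nitrogen, as in compound 1. The steps bearing on it are an at least 3.6-fold higher number from compound 1 to compound 3 (0.56 log units; beyond the scatter) and an at least 3.6-fold higher number from compound 1 to compound 2 (0.56 log units; beyond the scatter); the step that the two limits leave unreadable from compound 2 to compound 3 gives no readable size. A step of an at least 2.5-fold lower number from compound 3 to compound 4 (0.39 log units; beyond the scatter) is expected, back toward the level of compound 1. The estimate for compound 4 in this assay is 40000 nM, with a range of 12000 nM to 130000 nM.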

Compound 4, half-maximal inhibitory concentration: > 100000 nM
Compound 4: no number, only a limit; the forecaster's own chance of this, stated with the estimate: 40%; at least 2.5-fold (0.39 log units) between middle value and limit.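

A benzyl group on the ring nitrogen is not enough to give a number in this assay: compound 4 carries 3,4-dichlorobenzyl there and still gives only a limit. The change from 3-methylphenyl to 3,4-dichlorophenyl gives an at least 3.6-fold higher number from compound 1 to compound 4 (0.56 log units; beyond the scatter), which leaves compound 1 as the only compound shown with a number, and compound 4 joins the others at the limit: the limit of > 100000 nM in this assay, at which 3 of the 4 values shown sit. The steps from compound 3 to compound 4 and from compound 2 to compound 4 cannot be read.

No order among compound 2, compound 3 and compound 4 can be given. As far as these compounds go, whether a benzyl ring bearing a methoxy group or an amine would give a number at this nitrogen stays open.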